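Swapping the Aryl Group on a Hydrazone Tail

The source may hold more compounds than are shown below. What is called first, only, known or untested is meant among the compounds shown, and "the series" means these compounds.

Among the compounds with values here, compound 2 `O=C(N/N=C/c1cccc(Br)c1)Nc1cc2c(Nc3ccc(F)c(Cl)c3)ncnc2cc1O[C@H]1CCOC1` is the only compound here with a numbered result: in a functional assay on PC-3 cells (Homo sapiens) for cytotoxicity, read by MTT assay, with a stated time of 72 h (a lower number here means a stronger inhibitor, a higher number a weaker inhibitor), compound 2 gives 15500 nM. Compound 1 `O=C(N/N=C/c1ccc(F)cc1)Nc1cc2c(Nc3ccc(F)c(Cl)c3)ncnc2cc1O[C@H]1CCOC1` in this assay gives "not active" (no number reported), with no number given. Compound 3 `O=C(N/N=C/c1ccc(F)cc1Cl)Nc1cc2c(Nc3ccc(F)c(Cl)c3)ncnc2cc1O[C@H]1CCOC1` has not been measured; it differs from compound 2 in one place: 2-chloro-4-fluorophenyl in place of 3-bromophenyl on a carbon with a double bond to nitrogen. Within the data shown here, with no measured step to lean on, the expected step of a 1.4-fold higher number from compound 2 to compound 3 (0.15 log units; within the scatter) in this assay is toward a weaker result, though it may fall within the scatter. Compound 3 is estimated at 22000 nM, between 7000 nM and 70000 nM.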

Compound 3, half-maximal inhibitory concentration: 28400 nM
Estimate against measurement, compound 3: 1.3-fold (0.11 log units) below, within the range that was stated.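

Placing 2-chloro-4-fluorophenyl where 3-bromophenyl stood, on the carbon with a double bond to nitrogen, gives a 1.8-fold higher number from compound 2 to compound 3 (0.26 log units; within the scatter) in this assay. These two aryl groups, with different halogens at different ring positions, therefore cannot be told apart in this assay, so this pair offers no firm preference at this position. No available evidence bears on this result.

Within the data shown here, compound 1 has no number, so no step involving it can be read. On these data alone, it remains open whether a phenyl ring carrying an amine or a carboxylic acid in place of these halogens would give a clearly lower number.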